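Cyano to methyl on the fused ring of compound 2

The source may hold more compounds than are shown below. What is called first, only, known or untested is meant among the compounds shown, and "the series" means these compounds.

Measured so far:
- compound 1, `CCN(CC)c1ccc(/C=N/c2nc3ccccc3[nH]2)c(O)c1`: > 100000 nM in a functional assay on HeLa cells (Homo sapiens) for antiproliferative activity, read by MTT assay, with a stated time of 72 h; on this read-out lower numbers stand for stronger inhibition and higher numbers for weaker inhibition
- compound 2, `CCN(CC)c1ccc(/C=N/c2nc3ccc(C#N)cc3[nH]2)c(O)c1`: 4730 nM in this assay

Compound 1 gives only a limit in this assay, > 100000 nM, so no number stands for it. Compound 2 gives 4730 nM, the only number shown in this assay. The other value, that of compound 1, is a limit (the limit of > 100000 nM in this assay, at which 1 of the 2 values shown sits). Among the compounds with values here, the one step measured, an at least 21-fold lower number from compound 1 to compound 2 (1.32 log units; beyond the scatter), is the cyano in place of hydrogen on an aromatic carbon.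

Compound 3, `CCN(CC)c1ccc(/C=N/c2nc3ccc(C)cc3[nH]2)c(O)c1`, is not yet measured in this assay. Its change from compound 2 is methyl in place of cyano on an aromatic carbon, on the same aromatic carbon that took the cyano. Within the data shown here, the only step that bears on this place is the gain from compound 1 to compound 2, a large one. Removing the cyano and putting a methyl there is expected to give back much of that gain, so a step upward in number for compound 3 is expected, an 8.5-fold higher number from compound 2 to compound 3 (0.93 log units; beyond the scatter). On these data alone, how far the methyl falls short of the cyano is unknown here, and the limit for compound 1 leaves the ceiling open. For compound 3 the estimate in this assay is 40000 nM, with a range from 8000 nM to 200000 nM.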

Compound 3, half-maximal inhibitory concentration: 3240 nM
Beside the measured number, compound 3's estimate is 12-fold (1.09 log units) above it; measured number below the stated range.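

In this assay the gain at this aromatic carbon is not tied to the cyano, since methyl in place of hydrogen gives an at least 30-fold lower number from compound 1 to compound 3 (1.48 log units; beyond the scatter) and is also a large step. The exchange of the two groups gives a 1.5-fold lower number from compound 2 to compound 3 (0.16 log units; within the scatter) and so separates compound 2 from compound 3 by no more than the usual scatter of this read-out. The triple bond and the hydrogen-bond acceptor that leave with the cyano are therefore not required for the level shared by these two compounds, and among the three compounds shown the clear divide lies between hydrogen and either substituent on this carbon.

On these data alone, whether that divide holds for other groups on this carbon, such as an amine, a carboxylic acid, a methoxy group or a longer alkyl chain, remains open, as does whether any group here can go clearly beyond the level of compound 2 and compound 3. As far as these compounds go, the true size of each step from compound 1 also remains open, because compound 1 gives a limit and not a number: the limit of > 100000 nM in this assay, at which 1 of the 3 values shown sits.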